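Phenyl to cyclopropyl on the ring amide nitrogen

This account rests on a few compounds, and the source may have more. Where it says the series, first, only, none or still open, it means among the compounds named here.

Compound 1 `COc1ncc(-c2ccc3c(c2)N(c2ccccc2)C(=O)CO3)cc1NS(=O)(=O)c1ccc(F)cc1` and compound 3 `COc1ncc(-c2ccc3c(c2)N(C2CC2)C(=O)CO3)cc1NS(=O)(=O)c1ccc(F)cc1` share one core; compound 2 `O=C1COc2ccc(-c3cccc(NS(=O)(=O)c4ccc(F)cc4)c3)cc2N1c1ccccc1` and compound 4 `O=C1COc2ccc(-c3cccc(NS(=O)(=O)c4ccc(F)cc4)c3)cc2N1C1CC1` share another, and the difference between the two cores is not broken down here. In a functional assay on HCT-116 cells (Homo sapiens) for antiproliferative activity, read by MTT assay, with a stated time of 72 h (a lower number here means a stronger inhibitor, a higher number a weaker inhibitor), compound 1 gives 18800 nM and compound 3 gives 24300 nM. The change between them, (cyclopropyl in place of phenyl on an amide-type nitrogen in a ring), made a step of a 1.3-fold higher number from compound 1 to compound 3 (0.11 log units; within the scatter). For compound 2 only a limit of this assay is known, > 40000 nM; this sits at the limit of > 40000 nM in this assay, at which 1 of the 3 values shown sits.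

Compound 4 carries the same change on the second core, (cyclopropyl in place of phenyl on an amide-type nitrogen in a ring), with the place described in the same words for both pairs. The expectation for compound 4 rests on the measured pair, where compound 1 to compound 3 showed a 1.3-fold higher number from compound 1 to compound 3 (0.11 log units; within the scatter), and on the limit of compound 2 at > 40000 nM. The step from compound 2 to compound 4 is expected to be a step that the limit leaves unreadable from compound 2 to compound 4. Compound 4 is therefore estimated to give 52000 nM in this assay, within a range of 25000 nM to 120000 nM, most likely reported again as a limit rather than a number.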

Compound 4, half-maximal inhibitory concentration: > 40000 nM
Compound 4: a limit, no number; the forecaster's own chance of this, stated with the estimate: 75%; the middle value lies beyond the limit too.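

In this assay compound 4 gives > 40000 nM, a limit and not a number. Compound 2 also stands at a limit, so no step between compound 2 and compound 4 can be read: the limit of > 40000 nM in this assay, at which 2 of the 4 values shown sit.

The compounds shown leave open whether cyclopropyl in place of phenyl on the amide-type nitrogen changes activity on the core shared by compound 2 and compound 4, and by how much.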